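Anilide aryl swap to pyridin-2-yl in the benzamide series

A few compounds are considered here, and "the series" means these few. Any claim that something is new, unique, unknown or untested is made for them only; others in the source may bear on it.

Measured compounds:
compound 1 `CN1C[C@H](C(=O)Nc2ccc(F)cc2)[C@@H](c2ccc(/C=C/C(=O)Nc3ccccc3N)cc2)C1` — 34 mL/min/kg
compound 2 `CN1C[C@H](C(=O)Nc2ccc(Br)cc2)[C@@H](c2ccc(/C=C/C(=O)Nc3ccccc3N)cc2)C1` — 16 mL/min/kg
compound 3 `CN1C[C@H](C(=O)Nc2ccc(Cl)c(Cl)c2)[C@@H](c2ccc(/C=C/C(=O)Nc3ccccc3N)cc2)C1` — 36 mL/min/kg

In an in vitro ADME assay on microsomes from liver (Mus musculus) for pharmacokinetics, read by LC-MS, with a stated time of 10 min, tested at 1 uM (on this read-out higher numbers stand for fast clearance and lower numbers for slow clearance), compound 1 gives 34 mL/min/kg and stands second highest of the three numbers; compound 3 sits closest to it, and compound 2 furthest from it. The two steps that start from compound 1 are small: a 2.1-fold lower number from compound 1 to compound 2 (0.33 log units; beyond the scatter) and a 1.1-fold higher number from compound 1 to compound 3 (0.02 log units; within the scatter). Between the other two, a 2.3-fold higher number from compound 2 to compound 3 (0.35 log units; beyond the scatter).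

Compound 4 `CN1C[C@H](C(=O)Nc2ccccn2)[C@@H](c2ccc(/C=C/C(=O)Nc3ccccc3N)cc2)C1` differs from compound 1 by pyridin-2-yl in place of 4-fluorophenyl on an amide-type nitrogen. Within the data shown here, no measured step exchanges the carbon-only ring on that amide-type nitrogen for a ring with a hetero atom; the steps at hand only vary the halogen substituents and all stay modest or within the scatter. On that basis the expected change for compound 4 in this assay is small, a 1.1-fold lower number from compound 1 to compound 4 (0.05 log units; within the scatter), with no step beyond the scatter expected in either direction. The estimate for compound 4 is therefore 30 mL/min/kg, in the range 15 mL/min/kg to 60 mL/min/kg.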

Compound 4, clearance: 40 mL/min/kg
Beside the measured number, compound 4's estimate is 1.3-fold (0.12 log units) below it; the range from low to high includes it.
By their numbers in this assay, from the lowest: compound 2; then compounds 1, 3 and 4 (each within the scatter of the next).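

In this assay, the first ring with a hetero atom on the amide-type nitrogen stays within the scatter of the 4-fluorophenyl and 3,4-dichlorophenyl rings (see a 1.2-fold higher number from compound 1 to compound 4 (0.07 log units; within the scatter) and a 1.1-fold higher number from compound 3 to compound 4 (0.05 log units; within the scatter)). Only the 4-bromophenyl ring stands apart from it (see a 2.5-fold higher number from compound 2 to compound 4 (0.40 log units; beyond the scatter)), so among these four compounds, the one separated at this position remains compound 2, and the carbon-only ring is not needed for a number at the level of compound 1. Nothing at hand accounts for how little the ring exchange moves the number.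

From the compounds shown here alone, whether the gap to compound 2 belongs to the bromo group alone stays open, with an unsubstituted phenyl ring as the missing reference. Going by these compounds, how an amine or a carboxylic acid on the pyridin-2-yl ring would read also stays open.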